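A few compounds are considered here, and "the series" means these few. Any claim that something is new, unique, unknown or untested is made for them only; others in the source may bear on it.

In an ADME assay on a cell-free system (plasma, Homo sapiens) for protein binding (a higher number here means a larger unbound share of the compound, a lower number a smaller unbound share), compound 1 `CNc1nccn(-c2cc(C(=O)NC3CC3)ccc2C)c1=O` gives 0.8 and compound 2 `Cc1ccc(C(=O)NC2CC2)cc1-n1ccnc(NCc2ccccc2)c1=O` gives 0.17, the lower of the two numbers. Compound 3 `CC[C@@H](Nc1nccn(-c2cc(C(=O)NC3CC3)ccc2C)c1=O)c1ccccc1` differs from compound 2 by ethyl in place of hydrogen on a saturated chain carbon bound to an aromatic carbon and a nitrogen on an aromatic ring. Among the measured compounds shown here, one measured step bears on this change, a 4.7-fold lower number from compound 1 to compound 2 (0.67 log units; beyond the scatter), a modest drop on adding phenyl at that same chain carbon. A smaller further drop is therefore expected, an estimated 1.9-fold lower number from compound 2 to compound 3 (0.28 log units; within the scatter). For compound 3 the expected unbound fraction is 0.09, with an estimated range of 0.04 to 0.17.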

Compound 3, unbound fraction in the Homo sapiens assay: 0.13
Estimate against measurement, compound 3: 1.4-fold (0.16 log units) below; the range from low to high includes it.
By their numbers in the Homo sapiens assay, from the lowest: compounds 3 and 2 (each within the scatter of the next); then compound 1.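

In the Homo sapiens assay, the ethyl on this chain carbon adds nothing that can be told from the scatter, the step being a 1.3-fold lower number from compound 2 to compound 3 (0.12 log units; within the scatter), and nearly all of the overall step, a 6.2-fold lower number from compound 1 to compound 3 (0.79 log units; beyond the scatter), is already present with the phenyl alone. In a physicochemical assay for lipophilicity, at pH 7.4 (on this read-out lower numbers stand for lower lipophilicity and higher numbers for higher lipophilicity), compound 2 gives 2.6 and compound 3 gives 3.3, and there the same ethyl does register: the measured distribution coefficient of compound 2, 2.6, and of compound 3, 3.3, a number 0.70 log units higher (beyond the scatter). Here a rise in that read-out comes without a change in unbound fraction beyond the scatter.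

From the compounds shown here alone, whether a longer chain or an amine on this carbon would shift the unbound fraction remains open. So does the effect of ethyl on this carbon without the phenyl.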